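The compounds below may be only part of what the source reports. "The series", "measured", "known", "first", "only" and "open" are said of these compounds alone.

Measured so far:
- compound 1 `O=[N+]([O-])c1ccc(-c2nc3cc(C(F)(F)F)ccc3[nH]2)cc1`: 45000 nM
- compound 2 `CC(=O)Nc1ccc(-c2nc3cc(C(F)(F)F)ccc3n2C2CCCCC2)cc1`: 30000 nM

Both numbers come from an ADME assay on Vero cells (Chlorocebus sabaeus) for cytotoxicity (on this read-out lower numbers stand for higher toxicity in this test and higher numbers for lower toxicity in this test), so a low number means the compound harms the cells at a low concentration. Compound 2 gives the lowest of the two numbers, 30000 nM, but compound 1 sits within the scatter of it at 45000 nM, so the two compounds cannot be told apart on this read-out.

Compound 3 `CC(=O)Nc1ccc(-c2nc3cc(C(F)(F)F)ccc3[nH]2)cc1` has not yet been measured. It differs from compound 2 in one place: hydrogen in place of cyclohexyl on an aromatic nitrogen. Compound 1 already carries hydrogen on the same ring nitrogen, though with a different group on its other ring, and its number is not separated from that of compound 2 beyond the scatter. On that basis the expected step of a 1.5-fold higher number from compound 2 to compound 3 (0.18 log units; within the scatter) in this assay is small, leaning toward a higher number, and may well fall within the scatter. Compound 3 is therefore estimated at 45000 nM, with a range from 20000 nM to 100000 nM.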

Compound 3, half-maximal cytotoxic concentration: 50000 nM
For compound 3 the middle estimate is 1.1-fold (0.05 log units) below the measured one, and the stated range covers the measured number.
By their numbers in this assay, from the lowest: compounds 2, 1 and 3 (each within the scatter of the next).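

Replacing cyclohexyl with hydrogen on the aromatic nitrogen gives a 1.7-fold higher number from compound 2 to compound 3 (0.22 log units; within the scatter) in this assay, so removing this six-membered carbon ring from that position leaves no change that can be told apart from the usual spread of repeat measurements. With hydrogen on that same nitrogen, acetamido in place of nitro on an aromatic carbon gives a 1.1-fold higher number from compound 1 to compound 3 (0.05 log units; within the scatter), so this single change cannot be separated from the scatter either, and neither step gives a reason to link that group or cyclohexyl to the cell toxicity seen here. No supporting data are available to explain what lies behind these two small steps.

As far as these compounds go, it remains open whether a smaller or differently shaped group on the aromatic nitrogen, such as methyl, a longer carbon chain or a chain ending in an amine, would also stay within the scatter. From the compounds shown here alone, it is equally open whether a carboxylic acid or an amine in place of acetamido on the aromatic carbon would leave the read-out just as unchanged.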